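Trifluoromethyl on the Benzoyl Ring of a Carboxylic Acid

This account rests on a few compounds, and the source may have more. Where it says the series, first, only, none or still open, it means among the compounds named here.

Measured so far:
- compound 1 `COC(=O)c1ccc2ccc(C(=O)c3ccccc3)c-2cc1`: 7.2%
- compound 2 `COC(=O)c1ccc2ccc(C(=O)c3ccc(C(F)(F)F)cc3)c-2cc1`: -60.5%
- compound 3 `O=C(O)c1ccc2ccc(C(=O)c3ccccc3)c-2cc1`: 11%

These three compounds were tested in an assay on cells for displacement of a labelled ligand from Orexin/Hypocretin receptor type 1 (Homo sapiens), read by scintillation counting, with stated times of 10 min and 90 min, tested at 10 uM; a lower number here means less inhibition, a higher number more inhibition at the concentration tested (going by the name of the read-out). Compound 3 gives 11%, the highest of the three numbers, though the step of a number 3.8 percentage points higher from compound 1 to compound 3 (within the scatter) is within the scatter, so compound 1 and compound 3 cannot be told apart. Compound 2, at -60.5%, stands far below both.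

Compound 4 `O=C(O)c1ccc2ccc(C(=O)c3ccc(C(F)(F)F)cc3)c-2cc1` has not yet been measured. It differs from compound 3 in one place: trifluoromethyl in place of hydrogen on an aromatic carbon, on an aromatic carbon of a six-membered aromatic ring of carbon only, para to a large group.

The same change was measured once before, on the methyl ester: a number 67.7 percentage points lower from compound 1 to compound 2 (beyond the scatter), a large fall beyond the scatter. Since compound 3 and compound 1 differ only by hydrogen in place of methyl on an oxygen next to a carbonyl group, and that step was within the scatter, a fall of similar size is expected from compound 3 to compound 4 in this assay. The estimated step is a number 68 percentage points lower from compound 3 to compound 4 (beyond the scatter).

Compound 4 is therefore expected to give about -57%, with a likely range from -85% to -20%.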

Compound 4, a percentage reported as inhibition, at one concentration (the size of the read-out at that concentration, not a potency): -81.5%
Estimate against measurement, compound 4: 24.5 percentage points above, within the range that was stated.
By their numbers in this assay, from the lowest: compound 4; then compound 2; then compounds 1 and 3 (each within the scatter of the next).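

With trifluoromethyl in place of hydrogen on this aromatic carbon, para to a large group, the fall in this assay now appears on the carboxylic acid as well as on the methyl ester, with a number 92.5 percentage points lower from compound 3 to compound 4 (beyond the scatter). The same change therefore lowers the number on both cores, but by different amounts: the same change on two cores in this assay, a number 67.7 percentage points lower (beyond the scatter) from compound 1 to compound 2 and a number 92.5 percentage points lower (beyond the scatter) from compound 3 to compound 4, 24.8 percentage points apart, beyond the scatter of two such steps

Replacing the methyl of the ester with hydrogen also matters once trifluoromethyl is present, with a number 21 percentage points lower from compound 2 to compound 4 (beyond the scatter), so the two changes do not simply add up: the same change on two cores in this assay, a number 3.8 percentage points higher (within the scatter) from compound 1 to compound 3 and a number 21 percentage points lower (beyond the scatter) from compound 2 to compound 4, 24.8 percentage points apart, beyond the scatter of two such steps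

The compounds shown leave open whether a methyl group, a chlorine atom or an amine on this same carbon would also lower the number. They also cannot tell why the size of the fall differs between the two cores.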